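From a carboxy group to a butylsulfonyl group

This account rests on a few compounds, and the source may have more. Where it says the series, first, only, none or still open, it means among the compounds named here.

Three measured compounds share one core. Compound 1 `CCOC(=O)c1sc2nc(-c3cccs3)cc(-c3ccccc3)c2c1N` gives in an assay for inhibition of 15-hydroxyprostaglandin dehydrogenase [NAD(+)] (Homo sapiens), read by fluorescence, with a stated time of 15 min, in the presence of a further agent that is not named here (on this read-out lower numbers stand for stronger inhibition and higher numbers for weaker inhibition), only a limit, > 7500 nM. Compound 2 `CCCCSc1sc2nc(-c3cccs3)cc(-c3ccccc3)c2c1N` gives in this assay a limit, > 80 nM. Compound 3 `Nc1c(C(=O)O)sc2nc(-c3cccs3)cc(-c3ccccc3)c12` likewise gives in this assay a limit, > 7500 nM, so that compound 3 stands at the limit of > 7500 nM in this assay, at which 2 of the 3 values shown sit. The steps a step that the two limits leave unreadable from compound 1 to compound 3 and a step that the two limits leave unreadable from compound 2 to compound 3 run between limits and carry no readable size. Compound 4 `CCCCS(=O)(=O)c1sc2nc(-c3cccs3)cc(-c3ccccc3)c2c1N` differs from compound 3 by butylsulfonyl in place of carboxy on an aromatic carbon. For the measured compounds named here, no measured step gives a direction for this change, so the expectation is wide. Compound 4 is estimated at 2000 nM, within 200 nM to 10000 nM, an expected step of an at least 3.7-fold lower number from compound 3 to compound 4 (0.57 log units; beyond the scatter).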

Compound 4, half-maximal inhibitory concentration: 25 nM
The estimate for compound 4 lay 80-fold (1.90 log units) above the measured number, and the stated range ends above it.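

Butylsulfonyl on this aromatic carbon gives the first exact number for the shared core in this assay, so the position now shows that a change here can matter greatly. The change gives an at least 300-fold lower number from compound 3 to compound 4 (2.47 log units; beyond the scatter) and an at least 300-fold lower number from compound 1 to compound 4 (2.47 log units; beyond the scatter), both large, and even with the butyl chain kept, replacing butylsulfanyl gives an at least 3.2-fold lower number from compound 2 to compound 4 (0.50 log units; beyond the scatter). Each step starts from a limit, so each gives only a minimum size.

The steps among the three earlier compounds cannot be read, and no measurement shown accounts for the gain. On these data alone, whether ethylsulfonyl, a shorter chain, or an aminosulfonyl group would match butylsulfonyl stays open.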